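Oxime ether in place of pyridyl on the anilinomethyl-imidazoline

A few compounds are considered here, and "the series" means these few. Any claim that something is new, unique, unknown or untested is made for them only; others in the source may bear on it.

Measured so far:
compound 1 `Cc1ncc(-c2ccccc2NCC2=NCCN2)o1` — 110 nM
compound 2 `c1ccc(-c2ccccc2NCC2=NCCN2)nc1` — 6.76 nM

Among the compounds with values here, in a functional assay for activation of Alpha-1A adrenergic receptor (Homo sapiens), read by calcium flux (on this read-out lower numbers stand for an effect already at smaller amounts and higher numbers for an effect only at larger amounts of compound), compound 2 gives the lower of the two numbers, with compound 1 as its only neighbour at a 16-fold lower number from compound 1 to compound 2 (1.21 log units; beyond the scatter). Compound 3 `CC/C(=N/OC)c1ccccc1NCC1=NCCN1` carries a group of 6 heavy atoms (4 carbon, 1 nitrogen, 1 oxygen; no ring) in place of a group of 6 heavy atoms (5 carbon, 1 nitrogen; one six-membered aromatic ring with 1 hetero atom), on an aromatic carbon. Within the data shown here, no measured step exchanges an aromatic ring for an open chain at this position; the one step that touches the same carbon, a 16-fold lower number from compound 1 to compound 2 (1.21 log units; beyond the scatter), shows that the group there moves the number strongly. With the ring removed the number is expected to rise, by a 7.4-fold higher number from compound 2 to compound 3 (0.87 log units; beyond the scatter). For compound 3 the estimate in this assay is 50 nM, within 8 nM to 300 nM.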

Compound 3, half-maximal effective concentration: 87.1 nM
Compound 3: the middle estimate sits 1.7-fold (0.24 log units) below what was measured; the range from low to high includes it.
By their numbers in this assay, from the lowest: compound 2; then compounds 3 and 1 (each within the scatter of the next).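

The open chain can be read against both rings at this aromatic carbon: in this assay, the exchange for pyridin-2-yl gives a 13-fold higher number from compound 2 to compound 3 (1.11 log units; beyond the scatter), while the exchange for 2-methyl-1,3-oxazol-5-yl gives a 1.3-fold lower number from compound 1 to compound 3 (0.10 log units; within the scatter). An aromatic ring here is therefore not needed to reach the number seen with 2-methyl-1,3-oxazol-5-yl, and among these three compounds the low number belongs to pyridin-2-yl alone. No available evidence gives a reason for this.

Still open, as far as these compounds go, is whether a phenyl or pyridin-3-yl group would fall nearer compound 2 or compound 3. A longer chain on the oxime oxygen is equally unresolved.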